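The source may report more compounds than this note shows. Statements on the series, on what has been measured and on what is new or still open speak of the compounds shown alone.

Of the compounds shown here, two sharing one core have been tested in a functional assay on the whole organism for inhibition, with Lemna aequinoctialis as the target, tested at 1000 ug/mL; a lower number here means less inhibition of growth, a higher number more inhibition of growth at the concentration tested. Compound 1 `COc1ccc(NC(=S)N/N=C2\C(=O)Nc3ccc([N+](=O)[O-])cc32)cc1` gives 25% in this assay, and compound 2 `O=C1Nc2ccc([N+](=O)[O-])cc2/C1=N/NC(=S)Nc1ccc(I)cc1` gives 25%. The only measured step, no change at the digits printed from compound 1 to compound 2 (within the scatter), swapped one group on the outer aromatic ring for another and left the growth inhibition unchanged within the scatter, so compound 2 stands level with compound 1 on the numbers shown.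

Compound 3 `N#Cc1cccc(NC(=S)N/N=C2\C(=O)Nc3ccc([N+](=O)[O-])cc32)c1` differs from compound 2 in a single place: 3-cyanophenyl in place of 4-iodophenyl on an amide-type nitrogen. Going by the values given here, this is again an exchange of the group carried on the outer ring, the same kind of change as the one step measured so far. Because that step, no change at the digits printed from compound 1 to compound 2 (within the scatter), lay within the scatter, the expected step of no change at the digits printed from compound 2 to compound 3 (within the scatter) is likewise none beyond the scatter. Compound 3 is therefore expected to give about 25% in this assay, within a range from 10% to 40%.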

Compound 3, percent growth inhibition at one concentration: 25%
Compound 3: middle estimate and measured number agree at the digits printed, and the stated range covers the measured number.
By their numbers in this assay, from the lowest: compounds 1, 2 and 3 (each within the scatter of the next).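

In this assay, placing 3-cyanophenyl on the amide-type nitrogen in place of 4-iodophenyl gives no change at the digits printed from compound 2 to compound 3 (within the scatter) and placing it there in place of 4-methoxyphenyl gives no change at the digits printed from compound 1 to compound 3 (within the scatter) in the same read-out. This position has now carried three different aromatic groups, and the new one brings a nitrile with a triple bond and a hydrogen-bond acceptor, yet the three compounds remain within the scatter of one another. The evidence at hand offers no explanation for this result.

These three compounds say nothing about an outer ring bearing an amine or a carboxylic acid, or about a longer chain at this nitrogen in place of the ring. As far as these compounds go, the effect of changing the shared core also remains open, as every compound here carries the same core and only the outer group varies.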